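Compound 3 to Compound 4: the Methoxyphenyl Series

The source may report more compounds than this note shows. Statements on the series, on what has been measured and on what is new or still open speak of the compounds shown alone.

Of the compounds shown here, three sharing one core have been tested in an assay on isolated protein for inhibition of homeodomain-interacting protein kinase 1 (Homo sapiens), read by AlphaScreen, with a stated time of 1 h; a higher number here means a weaker inhibitor, a lower number a stronger inhibitor. Compound 1 `CCNC(=O)Nc1nccc2nc(-c3ccccc3)cnc12` carries an ethylcarbamoyl group on a nitrogen on an aromatic ring, and in this assay compound 1 gives only a limit of > 100000 nM. Compound 2 `COc1ccccc1Nc1nccc2nc(-c3ccccc3)cnc12` carries a 2-methoxyphenyl group in that place, and in this assay compound 2 also gives only a limit of > 100000 nM. Compound 3 `COc1cccc(Nc2nccc3nc(-c4ccccc4)cnc23)c1` carries a 3-methoxyphenyl group, and in this assay compound 3 likewise gives only a limit of > 100000 nM. Because all three values sit at the limit of > 100000 nM in this assay, at which 3 of the 3 values shown sit, the steps among them cannot be sized: a step that the two limits leave unreadable from compound 1 to compound 2, a step that the two limits leave unreadable from compound 1 to compound 3 and a step that the two limits leave unreadable from compound 2 to compound 3 all stay unreadable. Compound 4 `COc1ccc(Nc2nccc3nc(-c4ccccc4)cnc23)cc1` is not yet measured and differs from compound 3 by 4-methoxyphenyl in place of 3-methoxyphenyl on a nitrogen on an aromatic ring. Going by the values given here, no measured step shows how this change acts in this assay, and every value so far is a limit. Compound 4 is therefore expected to give about 150000 nM in this assay, within 40000 nM to 600000 nM, an expected step that the limit leaves unreadable from compound 3 to compound 4.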

Compound 4, half-maximal inhibitory concentration: > 100000 nM
Compound 4: only a limit was reported; the forecaster's own chance of this, stated with the estimate: 85%; the middle value is on the limit's open side.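

In this assay compound 4 gives > 100000 nM, which is a limit and not a number. Its steps from compound 1, compound 2 and compound 3 therefore cannot be read: the limit of > 100000 nM in this assay, at which 4 of the 4 values shown sit. The compounds shown leave open whether the 2-methoxyphenyl, 3-methoxyphenyl and 4-methoxyphenyl groups differ in their effect on inhibition at all.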